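Swapping piperidine for diethylamino on an inhibitor

The compounds below may be only part of what the source reports. "The series", "measured", "known", "first", "only" and "open" are said of these compounds alone.

Compound 1 `CCN(CC)CCNC(=O)CC(CC(=O)NC1Cc2ccccc2C1)c1ccc(Cl)cc1` gives 50500 nM in a functional assay on HeLa cells (Homo sapiens) for inhibition; on this read-out higher numbers stand for weaker inhibition and lower numbers for stronger inhibition
Compound 2 `CCN(C(=O)CC(CC(=O)NCCN1CCCCC1)c1ccc(Cl)cc1)C1Cc2ccccc2C1` gives 20400 nM in this assay

Compound 2 has the lower number of the two, and its gap to compound 1 lies beyond the usual scatter. Compound 3 `CCN(CC)CCNC(=O)CC(CC(=O)N(CC)C1Cc2ccccc2C1)c1ccc(Cl)cc1` differs from compound 2 by diethylamino in place of piperidin-1-yl on a saturated chain carbon, two bonds along the chain from an amide-type nitrogen and carries diethylamino in place of piperidin-1-yl on a saturated chain carbon, two bonds along the chain from an amide-type nitrogen. Going by the values given here, no measured pair shows this swap alone. Among the compounds with values here, compound 1, which also has 2-(diethylamino)ethyl, gives 50500 nM as the only guide. A small move towards weaker inhibition, within the scatter, is expected: a 1.3-fold higher number from compound 2 to compound 3 (0.11 log units; within the scatter) in this assay is the estimated step. Compound 3 is expected at 26000 nM with an estimated range from 9000 nM to 65000 nM for now.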

Compound 3, half-maximal inhibitory concentration: 24300 nM
Beside the measured number, compound 3's estimate is 1.1-fold (0.03 log units) above it; measured number inside the range.
By their numbers in this assay, from the lowest: compounds 2 and 3 (each within the scatter of the next); then compound 1.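

In this assay, a ring-opened diethylamino group stands in for piperidin-1-yl on this saturated chain carbon with no change beyond the scatter, a 1.2-fold higher number from compound 2 to compound 3 (0.08 log units; within the scatter). The second comparison isolates another site: ethyl in place of hydrogen on an amide-type nitrogen gives a modest step beyond the scatter, a 2.1-fold lower number from compound 1 to compound 3 (0.32 log units; beyond the scatter). Nothing measured here explains either result. On these data alone, whether morpholin-4-yl or pyrrolidin-1-yl would fit this chain carbon equally well remains open. So does whether methyl or propyl on that amide-type nitrogen would match ethyl.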